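A few compounds are considered here, and "the series" means these few. Any claim that something is new, unique, unknown or untested is made for them only; others in the source may bear on it.

Measured in a functional assay on the whole organism for antagonist activity, with Rattus norvegicus as the target; a higher number here means that more compound is needed for the effect, a lower number that less compound is needed:
- Compound 1 `Oc1nc2cc(C(F)(F)F)cnc2nc1O`: 27 mg/kg
- Compound 2 `[O-][n+]1c(Cl)c(Br)cc2nc(O)c(O)nc21`: 45 mg/kg

Only these two compounds have been measured so far. Compound 2, at 45 mg/kg, lies within the scatter of compound 1, at 27 mg/kg, so the numbers do not separate them. Compound 3 `[O-][n+]1c(Cl)c(C(F)(F)F)cc2nc(O)c(O)nc21` is the next to be examined in this assay. It carries trifluoromethyl in place of bromo on an aromatic carbon, ortho to a chloro group, and is otherwise the same as compound 2 (trifluoromethyl in place of bromo on an aromatic carbon). Among the compounds with values here, no measured pair differs in one place, so the data offer no direct guide to this change. Compound 1 also carries trifluoromethyl and gives 27 mg/kg, which offers only indirect support. No shift beyond the scatter is expected, and the estimated change is a 1.5-fold lower number from compound 2 to compound 3 (0.18 log units; within the scatter). For compound 3 the expected value is 30 mg/kg, with an estimated range from 10 mg/kg to 80 mg/kg.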

Compound 3, dose for half-maximal effect: 60 mg/kg
Compound 3: the middle estimate sits 2.0-fold (0.30 log units) below what was measured; measured number inside the range.
By their numbers in this assay, from the lowest: compounds 1, 2 and 3 (each within the scatter of the next, the first and the last beyond it).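

In this assay, trifluoromethyl in place of bromo on an aromatic carbon, ortho to a chloro group, gives a 1.3-fold higher number from compound 2 to compound 3 (0.12 log units; within the scatter). Within the data shown here, this is the first direct comparison at this position, and it does not tell the two groups apart, even though trifluoromethyl has 4 heavy atoms where bromo has 1. Nothing at hand bears on why the two compounds read alike.

From the compounds shown here alone, what an amine, a carboxylic acid or a longer chain would do at this position remains open, as both groups compared here carry no hydrogen-bond donors or acceptors. Also open, going by these compounds, is whether the change would read the same without the chloro group, as compound 1 differs from compound 3 in more than one place and cannot settle it.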